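Swapping 4-methoxyphenyl for pyridin-3-yl in a cytotoxicity test

The source may report more compounds than this note shows. Statements on the series, on what has been measured and on what is new or still open speak of the compounds shown alone.

- Compound 1 `O=C(CCC1CCCCC1)OCCc1c(-c2ccccc2Cl)c2cc(Cl)ccc2[nH]c1=O`: 160000 nM
- Compound 2 `O=C(CN1C(=O)c2ccccc2C1=O)OCCc1c(-c2ccccc2Cl)c2cc(Cl)ccc2[nH]c1=O`: 960000 nM
- Compound 3 `COc1ccc(/C=C/C(=O)OCCc2c(-c3ccccc3Cl)c3cc(Cl)ccc3[nH]c2=O)cc1`: > 1200000 nM (a limit of the assay, not a number)

All three values come from an ADME assay on HepG2 2.2.15 cells (Homo sapiens) for cytotoxicity (on this read-out higher numbers stand for lower toxicity in this test and lower numbers for higher toxicity in this test), and the compounds share one core. Compound 3 has no exact place on this scale, only a limit (the limit of > 1200000 nM in this assay, at which 1 of the 3 values shown sits).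

Compound 4 (`O=C(/C=C/c1cccnc1)OCCc1c(-c2ccccc2Cl)c2cc(Cl)ccc2[nH]c1=O`) differs from it in one place (pyridin-3-yl in place of 4-methoxyphenyl on a double-bonded chain carbon bound to a double-bonded chain carbon). Pyridin-3-yl stands in place of 4-methoxyphenyl, on a double-bonded chain carbon bound to a double-bonded chain carbon.

Among the measured compounds shown here, no measured step makes this exact swap, so the evidence is indirect. Moving away from the 2-cyclohexylethyl group gave an at least 7.5-fold higher number from compound 1 to compound 3 (0.87 log units; beyond the scatter), and a different replacement gave a 6.0-fold higher number from compound 1 to compound 2 (0.78 log units; beyond the scatter). Both raised the number, which means lower toxicity in this test. Two quite different groups, however, are not separated by the data (an at least 1.2-fold higher number from compound 2 to compound 3 (0.09 log units; that floor lies within the scatter)). Compound 4 keeps the 2-arylethenyl shape of compound 3, with only the ring changed, so a large move seems unlikely. The estimated change is an at least 1.0-fold lower number from compound 3 to compound 4 (0.03 log units; that floor lies within the scatter), which means no step beyond the scatter is expected. For compound 4 the expected value is 1100000 nM (estimated range 400000 nM to 2500000 nM).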

Compound 4, half-maximal cytotoxic concentration: 39000 nM
Compound 4: the middle estimate sits 28-fold (1.45 log units) above what was measured; the whole stated range lies above it.
By their numbers in this assay, from the lowest: compound 4; then compound 1; then compound 2. At a limit, above all of these: compound 3.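

In this assay, the ring on the double-bonded chain carbon turns out to matter a great deal: with the 2-arylethenyl shape kept, pyridin-3-yl in place of 4-methoxyphenyl gives an at least 30-fold lower number from compound 3 to compound 4 (1.48 log units; beyond the scatter), and a lower number here means higher toxicity in this test. Compound 3 sits only at a limit, so this step gives a floor and not an exact size: the limit of > 1200000 nM in this assay, at which 1 of the 4 values shown sits.

The earlier compounds shown here showed only rising numbers on moving away from 2-cyclohexylethyl, but compound 4 goes against that pattern, with a 4.1-fold lower number from compound 1 to compound 4 (0.61 log units; beyond the scatter), and it also parts clearly from the phthalimide-bearing compound, with a 25-fold lower number from compound 2 to compound 4 (1.39 log units; beyond the scatter).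

The compounds shown leave open whether the large step follows from gaining the ring nitrogen or from losing the methoxy group, and an unsubstituted phenyl ring at this place would help separate the two. They also do not show whether the placement of the ring nitrogen matters, which pyridin-2-yl or pyridin-4-yl could test.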